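Nitrophenyl Variant of the Shared Core

This account rests on a few compounds, and the source may have more. Where it says the series, first, only, none or still open, it means among the compounds named here.

Measured compounds:
Compound 1, `O=C1Nc2ccc(Cl)cc2/C1=N/NC(=S)N1CCN(c2ccccc2)CC1`, gives 7340 nM in a functional assay on A549 cells (Homo sapiens) for inhibition, read by MTT assay, with a stated time of 72 h; a higher number here means a weaker inhibitor, a lower number a stronger inhibitor.
Compound 2, `O=C1Nc2ccc(Cl)cc2/C1=N/NC(=S)N1CCN(c2ccccc2Cl)CC1`, gives 7920 nM in this assay.

Among the measured compounds shown here, compound 2 stands at the top of the two numbers, but the only measured step, a 1.1-fold higher number from compound 1 to compound 2 (0.03 log units; within the scatter), lies within the scatter, so the two compounds cannot be separated. Compound 3, `O=C1Nc2ccc(Cl)cc2/C1=N/NC(=S)N1CCN(c2ccc([N+](=O)[O-])cc2)CC1`, has not yet been measured in this assay. It differs from compound 2 by 4-nitrophenyl in place of 2-chlorophenyl on an amine nitrogen in a ring. For the measured compounds named here, the single step that bears on this position is the one from compound 1 to compound 2, a substituent change on the same ring that left the number where it was. Going by the values given here, nothing among the measured compounds suggests a direction for a larger swap at this ring, so compound 3 is expected to show a 1.1-fold lower number from compound 2 to compound 3 (0.02 log units; within the scatter), no step beyond the scatter. Compound 3 is therefore estimated at 7500 nM in this assay, with a range from 3000 nM to 19000 nM.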

Compound 3, half-maximal inhibitory concentration: 11800 nM
The estimate for compound 3 lay 1.6-fold (0.20 log units) below the measured number; the range from low to high includes it.
By their numbers in this assay, from the lowest: compounds 1, 2 and 3 (each within the scatter of the next).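

In this assay, the larger swap at this ring nitrogen also stays within the scatter: replacing 2-chlorophenyl with 4-nitrophenyl gives a 1.5-fold higher number from compound 2 to compound 3 (0.17 log units; within the scatter) and placing nitro on the plain phenyl ring gives a 1.6-fold higher number from compound 1 to compound 3 (0.21 log units; within the scatter) as the second reading. Earlier, only a chloro substituent on this ring had been compared, whereas now two different groups, at two different places on the ring, leave the number indistinguishable from that of the plain phenyl ring in compound 1. No evidence is available that bears on this result.

The compounds shown leave open whether an amine or a carboxylic acid on this ring would give a step beyond the scatter. They also leave open what would follow if a saturated ring or a longer chain took the place of the phenyl ring on the ring nitrogen.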